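Shortening the amine tail on the shared core

The compounds below may be only part of what the source reports. "The series", "measured", "known", "first", "only" and "open" are said of these compounds alone.

Compound 1 `CN1CCN(CCCCCCn2c3c(c4ccccc42)C(=O)c2c[n+]([O-])c4ccccc4c2C3=O)CC1`: 920 nM in a functional assay on SH-SY5Y cells (Homo sapiens) for cytotoxicity, read by MTT assay, with a stated time of 72 h; on this read-out lower numbers stand for stronger inhibition and higher numbers for weaker inhibition
Compound 2 `O=C1c2c[n+]([O-])c3ccccc3c2C(=O)c2c1c1ccccc1n2CCCCN1CCCCC1`: 230 nM in this assay
Compound 3 `CCCCN1CCN(CCCCn2c3c(c4ccccc42)C(=O)c2c[n+]([O-])c4ccccc4c2C3=O)CC1`: 6100 nM in this assay

Compound 3 stands highest of the three numbers, with a 27-fold higher number from compound 2 to compound 3 (1.42 log units; beyond the scatter) and a 6.6-fold higher number from compound 1 to compound 3 (0.82 log units; beyond the scatter). Compound 4 `CN(C)CCCCCn1c2c(c3ccccc31)C(=O)c1c[n+]([O-])c3ccccc3c1C2=O` differs from compound 3 by (dimethylamino)methyl in place of 4-butylpiperazin-1-yl on a saturated chain carbon, four bonds along the chain from an aromatic nitrogen. Both measured steps that end at compound 3 bear on this: replacing a smaller amine by 4-butylpiperazin-1-yl raised the number by a modest to large margin, so removing that group for a small (dimethylamino)methyl is expected to lower the number beyond the scatter, toward the values of compound 2 and compound 1. Compound 4 is therefore estimated at 450 nM, with a range of 150 nM to 1500 nM, which would mean an expected step of a 14-fold lower number from compound 3 to compound 4 (1.13 log units; beyond the scatter).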

Compound 4, half-maximal inhibitory concentration: 370 nM
Compound 4: middle estimate off by 1.2-fold (0.09 log units), on the high side; low and high end bracket the measured number.
By their numbers in this assay, from the lowest: compounds 2 and 4 (each within the scatter of the next); then compound 1; then compound 3.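

In this assay, (dimethylamino)methyl in place of 4-butylpiperazin-1-yl gives a 16-fold lower number from compound 3 to compound 4 (1.22 log units; beyond the scatter) on a saturated chain carbon, and dimethylamino in place of (4-methylpiperazin-1-yl)methyl gives a 2.5-fold lower number from compound 1 to compound 4 (0.40 log units; beyond the scatter) further along the chain. Set against piperidin-1-yl, (dimethylamino)methyl gives a 1.6-fold higher number from compound 2 to compound 4 (0.21 log units; within the scatter) so at this place an amine tail with no ring matches the ringed tail of compound 2 within the scatter. No measurement shown offers an explanation for these steps. The compounds shown leave open how a morpholine or a primary amine would read at this place, and whether the butyl group alone accounts for the high number of compound 3.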